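Extending the side chain from compound 3 to compound 4

This account rests on a few compounds, and the source may have more. Where it says the series, first, only, none or still open, it means among the compounds named here.

In a functional assay on MCF7 cells (Homo sapiens) for antiproliferative activity (a higher number here means a weaker inhibitor, a lower number a stronger inhibitor), compound 1 (`O=C(Nc1ccc(O)c2c(=O)cc(-c3ccccc3Cl)oc12)c1ccc(Cl)c(Cl)c1`) gives 15000 nM while compound 2 (`COc1ccc(C(=O)Nc2ccc(O)c3c(=O)cc(-c4ccccc4Cl)oc23)cc1`) gives 3500 nM and compound 3 (`C[C@@H](NC(=O)OC(C)(C)C)C(=O)Nc1ccc(O)c2c(=O)cc(-c3ccccc3Cl)oc12`) gives 5500 nM in the same read-out. Compound 3 lies within the scatter of compound 2 and beyond the scatter below compound 1. Compound 4 (`CC(C)C[C@@H](NC(=O)OC(C)(C)C)C(=O)Nc1ccc(O)c2c(=O)cc(-c3ccccc3Cl)oc12`) carries isopropyl in place of hydrogen on a saturated chain carbon, counted as isopropyl in place of hydrogen on a saturated chain carbon, two bonds along the chain from an amide-type nitrogen and a carbonyl carbon with the rest unchanged. Going by the values given here, no measured step alters this chain. The closest are changes on a carbonyl carbon, where a 2.7-fold lower number from compound 1 to compound 3 (0.44 log units; beyond the scatter) is modest and a 1.6-fold higher number from compound 2 to compound 3 (0.20 log units; within the scatter) stays within the scatter. In this assay the expected outcome is a 1.1-fold lower number from compound 3 to compound 4 (0.04 log units; within the scatter) and thus no step beyond the scatter. For compound 4 the estimated value is 5000 nM with an expected range from 2000 nM to 13000 nM for now.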

Compound 4, half-maximal inhibitory concentration: 2500 nM
Estimate against measurement, compound 4: 2.0-fold (0.30 log units) above; the range from low to high includes it.
By their numbers in this assay, from the lowest: compounds 4, 2 and 3 (each within the scatter of the next, the first and the last beyond it); then compound 1.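

In this assay, the first change measured at this chain carbon, isopropyl in place of hydrogen, gives a 2.2-fold lower number from compound 3 to compound 4 (0.34 log units; beyond the scatter) and so is modest but beyond the scatter. Going by these compounds alone, the earlier steps all lay on a carbonyl carbon, so this is the first sign that the saturated chain carbon also affects the read-out. Nothing at hand explains the step.

Open, going by these compounds, is whether a longer chain, such as n-hexyl, or a benzyl group at this carbon moves the number further. Also open, on these data alone, is whether an amine or a carboxylic acid there is accepted.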